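A few compounds are considered here, and "the series" means these few. Any claim that something is new, unique, unknown or untested is made for them only; others in the source may bear on it.

Going by the values given here, compound 2 `O=c1c(C2N=C(c3ccccc3)SS2)coc2ccc(Cl)cc12` is the only compound here with a number: in a functional assay on PC-3 cells (Homo sapiens) for inhibition, read by sulforhodamine B assay, with a stated time of 48 h (on this read-out lower numbers stand for stronger inhibition and higher numbers for weaker inhibition), compound 2 gives 52700 nM. Compound 1 `Cc1ccc2occ(C3N=C(c4ccccc4)SS3)c(=O)c2c1` is different; in this assay compound 1 gives > 100000 nM, which is a limit of the assay and not a number. Among the compounds with values here, the one measured step, an at least 1.8-fold lower number from compound 1 to compound 2 (0.27 log units; that floor lies within the scatter), is therefore bounded by the limit of > 100000 nM in this assay, at which 1 of the 2 values shown sits. Compound 3 `O=c1c(C2N=C(c3ccccc3)SS2)coc2ccc(F)cc12` differs from compound 2 by fluoro in place of chloro on an aromatic carbon. Within the data shown here, no measured step exchanges one halogen for another, so no step beyond the scatter is expected in this assay. Compound 3 is expected to give 70000 nM, within 30000 nM to 200000 nM. For compound 3 the estimated step is a 1.3-fold higher number from compound 2 to compound 3 (0.12 log units; within the scatter).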

Compound 3, half-maximal inhibitory concentration: > 100000 nM
Compound 3: a limit, no number; the forecaster's own chance of this, stated with the estimate: 35%; middle value at least 1.4-fold (0.15 log units) away from the limit.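

With fluoro in place of chloro on this aromatic carbon, this assay shows an at least 1.8-fold higher number from compound 2 to compound 3 (0.27 log units; that floor lies within the scatter), so an exchange of one halogen for the other now has a measured floor. The step between compound 1 and compound 3 cannot be read, as both values are limits. Chloro, in compound 2, remains the only group at this place with a number: the limit of > 100000 nM in this assay, at which 2 of the 3 values shown sit.

Going by these compounds, whether chloro truly differs from fluoro or methyl stays open. So does how an amine or a carboxylic acid on this aromatic carbon would read in this assay.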